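Swapping the Thiophene for an Aminophenyl Arm

The source may report more compounds than this note shows. Statements on the series, on what has been measured and on what is new or still open speak of the compounds shown alone.

Among the measured compounds shown here, compound 1 `COC(=O)c1sc2cc(-c3ccsc3)cnc2c1N` is assessed in a functional assay on A-375 cells (Homo sapiens) for inhibition, read by sulforhodamine B assay, with a stated time of 48 h (a higher number here means a weaker inhibitor of growth, a lower number a stronger inhibitor of growth), where compound 1 gives 12100 nM, the only actual number among the two values at hand. Compound 2 `COC(=O)c1sc2cc(-c3ccc(OC)cc3)cnc2c1N` is reported in this assay only as a limit, > 150000 nM. Compound 1 thus stands as the sole measured figure, with the other value sitting at the limit of > 150000 nM in this assay, at which 1 of the 2 values shown sits. Compound 3 `COC(=O)c1sc2cc(-c3cccc(N)c3)cnc2c1N` differs from compound 1 by 3-aminophenyl in place of thiophen-3-yl on an aromatic carbon. For the measured compounds named here, no step between two measured compounds exists, so a direct reference is lacking. Compound 2 reaching only a limit, > 150000 nM, argues for a weaker compound 3. Compound 3 is therefore expected to lose ground, by a step of a 3.3-fold higher number from compound 1 to compound 3 (0.52 log units; beyond the scatter). The estimate for compound 3 is 40000 nM, within 10000 nM to 150000 nM.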

Compound 3, concentration for 50% growth inhibition: > 150000 nM
Compound 3 gave a limit, no number; the forecaster's own chance of this, stated with the estimate: 35%; middle value at least 3.7-fold (0.57 log units) from the limit.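

In this assay, among the compounds shown here, 3-aminophenyl in place of thiophen-3-yl, two atoms from the ring nitrogen, gives an at least 12-fold higher number from compound 1 to compound 3 (1.09 log units; beyond the scatter), the first step between measured compounds that can be read at this position. The reading for compound 3, > 150000 nM, is a limit and not a number, and such readings now make up most of the set: the limit of > 150000 nM in this assay, at which 2 of the 3 values shown sit. Among the compounds shown, only the thiophen-3-yl of compound 1 gives an actual number here. Going by these compounds, how far compound 3 lies beyond its limit stays open. So does whether an unsubstituted phenyl or a thiophen-2-yl at this position would give a number.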